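Replacing an Acetamido Group with Dipropylamino

The source may report more compounds than this note shows. Statements on the series, on what has been measured and on what is new or still open speak of the compounds shown alone.

Of the compounds shown here, three sharing one core have been tested in a functional assay on the whole organism with Rattus norvegicus as the target; a lower number here means that less compound is needed, a higher number that more compound is needed for the effect. Compound 1 `Cc1nc2c(OCc3ccc(Cl)cc3)cccn2c1N` gives 2.2 mg/kg. Compound 2 `Cc1nc2c(OCCc3ccccc3)cccn2c1N` gives 5.2 mg/kg. Compound 3 `CC(=O)Nc1c(C)nc2c(OCc3ccccc3)cccn12` gives 4.6 mg/kg, the second highest of the three numbers; its gap to compound 2 lies within the usual scatter, while compound 1 sits beyond the scatter at a lower number. Going by the values given here, no pair of measured compounds differs in only one place, so no measured step is available for calibration. Compound 4 `CCCN(CCC)c1c(C)nc2c(OCc3ccccc3)cccn12` differs from compound 3 in one place: dipropylamino in place of acetamido on an aromatic carbon. With nothing measured to lean on, the step in this assay is expected to be modest and toward a higher number. The expected step is a 1.7-fold higher number from compound 3 to compound 4 (0.24 log units; within the scatter). Compound 4 is therefore estimated at 8 mg/kg, ranging from 2.5 mg/kg to 25 mg/kg.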

Compound 4, dose for half-maximal effect: 8.4 mg/kg
Estimate against measurement, compound 4: 1.1-fold (0.02 log units) below; the measured number falls inside the stated range.
By their numbers in this assay, from the lowest: compound 1; then compounds 3, 2 and 4 (each within the scatter of the next).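

In this assay, going by these compounds alone, swapping acetamido for dipropylamino on this aromatic carbon gives a 1.8-fold higher number from compound 3 to compound 4 (0.26 log units; within the scatter), the first comparison that changes only one place. The change adds heavy atoms and removes the hydrogen-bond donor, yet the dose needed shows no clear shift, so this position tolerates the exchange in this assay. No supporting measurement is available to explain this result.

The compounds shown leave open how a smaller dimethylamino group, a morpholine ring or a carboxylic acid would fare at this position.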